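Benzyl amide replacing a hydrazide on a cytotoxicity screen

The source may report more compounds than this note shows. Statements on the series, on what has been measured and on what is new or still open speak of the compounds shown alone.

Compound 1 (`CC(C)(NC(=O)OCc1ccccc1)c1nc(O)c(O)c(C(=O)NN)n1`) is assessed in an ADME assay on C8166 cells (Homo sapiens) for cytotoxicity, read by MTT assay, with a stated time of 3 days; a lower number here means that less compound is tolerated, a higher number that more compound is tolerated. In this assay compound 1 reaches only the limit of the measurement, giving > 500000 nM, which is not a number but the highest concentration tested. Compound 2 (`CC(C)(NC(=O)OCc1ccccc1)c1nc(O)c2oc(=O)[nH]c2n1`), which carries a cyclised version of the same side of the core, is known in this assay by its limit as well, > 500000 nM. Both values therefore sit at the same boundary, as summarised by the limit of > 500000 nM in this assay, at which 2 of the 2 values shown sit, and compound 1 cannot be placed above or below compound 2 on these numbers.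

Compound 3 (`CC(C)(NC(=O)OCc1ccccc1)c1nc(O)c(O)c(C(=O)NCc2ccccc2)n1`) is still to be measured in this assay. It differs from compound 1 by benzyl in place of amino on an amide-type nitrogen. Within the data shown here, with both known compounds sitting at the limit, no step between measured compounds is available to guide the expectation; the working expectation is a step of no more than the scatter in either direction, an at least 1.2-fold lower number from compound 1 to compound 3 (0.09 log units; that floor lies within the scatter). For compound 3 the estimated value is 400000 nM, with a range from 100000 nM to 1000000 nM.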

Compound 3, half-maximal cytotoxic concentration: 41400 nM
Compound 3: middle estimate off by 9.7-fold (0.99 log units), on the high side, and the stated range ends above it.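

In this assay, benzyl in place of amino on an amide-type nitrogen gives an at least 12-fold lower number from compound 1 to compound 3 (1.08 log units; beyond the scatter), so this position of the core of compound 1 is not silent in this read-out, and the change takes the series off its ceiling. The earlier compounds shown here could not show this, since the value of compound 1, > 500000 nM, is a limit of the assay, and the step can be read only as a lower bound on the size of the change. Compound 3 is the only compound shown with a measured number rather than a boundary value, which sets it apart from the other two: the limit of > 500000 nM in this assay, at which 2 of the 3 values shown sit.

The compounds shown leave open whether the lower number goes with the aromatic ring of the benzyl group or simply with the larger carbon-only group on that nitrogen, which a cyclohexylmethyl or a plain butyl group in the same place would separate. Among these compounds, they also leave open how the amide-type nitrogen itself contributes, since a carboxylic acid at that carbonyl carbon has no counterpart among them.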